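Swapping a Carbamate Cap for a Sulfonamide

The source may report more compounds than this note shows. Statements on the series, on what has been measured and on what is new or still open speak of the compounds shown alone.

Compound 1 `CC(C)(C)OC(=O)N1CCC(Oc2cccc3c2CCN3c2ccc(S(C)(=O)=O)cc2)CC1`: 158 nM
Compound 2 `CC(C)OC(=O)N1CCC(Oc2ncnc3c2CCN3c2ccc(-c3nccs3)cc2F)CC1`: 79.4 nM
Compound 3 `CCCOC(=O)N1CCC(Oc2ncnc3c2CCN3c2ccc(S(C)(=O)=O)cc2F)CC1`: 79.4 nM

All three were tested in a functional assay on CHO-K1 cells for agonist activity at Glucose-dependent insulinotropic receptor (Homo sapiens), read by a luciferase reporter, with a stated time of 5 h; a lower number here means that less compound is needed, a higher number that more compound is needed for the effect. Compound 3 gives 79.4 nM in this assay, level with compound 2 at the digits shown, and these two are together the lowest numbers of the three. The number for compound 1 differs from that of compound 3 by no more than the usual scatter, so the three measured compounds sit close together.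

Compound 4 `CCS(=O)(=O)N1CCC(Oc2ncnc3c2CCN3c2ccc(S(C)(=O)=O)cc2F)CC1` has not yet been measured. It differs from compound 3 in one place: ethylsulfonyl in place of propoxycarbonyl on an amine nitrogen in a ring. The cap on the ring nitrogen changes, while the rest of the molecule, including the shared core, stays the same.

Among the measured compounds shown here, no measured pair here shows what such a change does, so the expectation rests only on the closeness of the three numbers. A modest step is expected, a 1.5-fold higher number from compound 3 to compound 4 (0.18 log units; within the scatter), likely within the scatter, with a slight lean toward a higher number. Compound 4 is therefore estimated to give 120 nM in this assay, with a range from 40 nM to 400 nM.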

Compound 4, half-maximal effective concentration: 1580 nM
For compound 4 the middle estimate is 13-fold (1.12 log units) below the measured one, and the stated range ends below it.
By their numbers in this assay, from the lowest: compounds 2, 3 and 1 (each within the scatter of the next); then compound 4.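

The cap on the ring nitrogen turns out to matter a great deal in this assay: ethylsulfonyl in place of propoxycarbonyl brings a 20-fold higher number from compound 3 to compound 4 (1.30 log units; beyond the scatter). The earlier compounds shown here could not show this, as all three carry a cap ending in an oxycarbonyl group and no two of them differ in one place. The two caps match in their counts of hydrogen-bond donors and acceptors and carry no net charge, so those counts do not separate them, and nothing measured here accounts for the step.

Open, as far as these compounds go, is whether the sulfonyl link or the shorter chain matters more, since the change alters both at once. An ethoxycarbonyl cap, or a propylsulfonyl cap, would separate the two, and a simple acyl cap such as propanoyl would test the oxygen of the carbamate.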